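The compounds below may be only part of what the source reports. "The series", "measured", "known", "first", "only" and "open" are said of these compounds alone.

Compound 1 `COc1ccc(-c2cn3ccnc3c(-c3ccc4ncn(C5CCCCC5)c4c3)n2)cc1` carries a 4-methoxyphenyl group on the shared core, and in a functional assay on SK-MEL-5 cells (Homo sapiens) for inhibition, read by sulforhodamine B assay, with a stated time of 48 h, tested at 10 uM (on this read-out lower numbers stand for less inhibition and higher numbers for more inhibition at the one concentration tested (going by the name of the read-out)), compound 1 gives 92.3%. Compound 2 `Fc1ccc(-c2cn3ccnc3c(-c3ccc4ncn(C5CCCCC5)c4c3)n2)cc1` differs from it by fluoro in place of methoxy on an aromatic carbon; in this assay compound 2 gives 7.36%, a step of a number 84.9 percentage points lower from compound 1 to compound 2 (beyond the scatter). Compound 3 `COc1ccccc1-c1cn2ccnc2c(-c2ccc3ncn(C4CCCCC4)c3c2)n1` has the same atoms as compound 1 joined differently, namely (2-methoxyphenyl in place of 4-methoxyphenyl on an aromatic carbon). In this assay compound 3 gives 8.94%, so that a number 83.4 percentage points lower from compound 1 to compound 3 (beyond the scatter). Compound 2 and compound 3 lie close together, since a number 1.6 percentage points higher from compound 2 to compound 3 (within the scatter).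

Compound 4 `Fc1ccccc1-c1cn2ccnc2c(-c2ccc3ncn(C4CCCCC4)c3c2)n1` has not been measured. It differs from compound 3 by fluoro in place of methoxy on an aromatic carbon. Going by the values given here, this is the same kind of change as the one from compound 1 to compound 2, but not the same: in the earlier pair the changed carbon is para to a large group, whereas here it is ortho to a large group. The earlier step, a number 84.9 percentage points lower from compound 1 to compound 2 (beyond the scatter), was large, yet it began from a high number. Compound 3 already stands low, and little room remains for a fall of that size. A small step is expected here, a number 3.9 percentage points lower from compound 3 to compound 4 (within the scatter), resting on compound 3 at 8.94% and on the earlier pair being of the same kind only. Compound 4 is expected to give 5%, most likely between 0% and 25%.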

Compound 4, a percentage reported as inhibition, at one concentration (the size of the read-out at that concentration, not a potency): 6.5%
Beside the measured number, compound 4's estimate is 1.5 percentage points below it, within the range that was stated.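

The swap of methoxy for fluoro does not carry over from one core to the other in this assay: the same change on two cores in this assay, a number 84.9 percentage points lower (beyond the scatter) from compound 1 to compound 2 and a number 2.4 percentage points lower (within the scatter) from compound 3 to compound 4, 82.5 percentage points apart, beyond the scatter of two such steps. In these four compounds, the high number goes only with the 4-methoxyphenyl group of compound 1, as a number 85.8 percentage points lower from compound 1 to compound 4 (beyond the scatter), whereas the two fluoro compounds cannot be told apart, with a number 0.9 percentage points lower from compound 2 to compound 4 (within the scatter), and the same holds for the 2-methoxyphenyl and 2-fluorophenyl pair, with a number 2.4 percentage points lower from compound 3 to compound 4 (within the scatter). Going by these compounds alone, this shows that the effect of the swap depends on where the group sits, but with only two pairs it does not show why the steps differ, nor how the swap would behave on any other core.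

The compounds shown leave open whether another group in the place that the methoxy holds in compound 1, such as ethoxy, a dimethylamino group or a carboxylic acid, would also give a high number. They also leave open whether a change elsewhere on the core of compound 1 would keep its number.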